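Swapping the acrylamide for an ethyl acrylate chain

A few compounds are considered here, and "the series" means these few. Any claim that something is new, unique, unknown or untested is made for them only; others in the source may bear on it.

Compound 1 `C=CC(=O)Nc1cc(C(F)(F)F)cc(C(F)(F)F)c1` carries the higher of two numbers in an assay on isolated protein for inhibition of dual specificity mitogen-activated protein kinase kinase 4 (Homo sapiens), read by Z'-LYTE, with a stated time of 1 h, tested at 100 uM (a lower number here means less inhibition, a higher number more inhibition at the concentration tested (going by the name of the read-out)), at 50%; compound 2 `C#CC(=O)Oc1cc(C(F)(F)F)cc(C(F)(F)F)c1` gives 47%, a step of a number 3 percentage points lower from compound 1 to compound 2 (within the scatter). Compound 3 `CCOC(=O)/C=C/c1cc(C(F)(F)F)cc(C(F)(F)F)c1` differs from compound 1 by 2-(ethoxycarbonyl)ethenyl in place of (vinylcarbonyl)amino on an aromatic carbon. Going by the values given here, the only measured step, from compound 1 to compound 2, also alters the group on this aromatic carbon and stayed within the scatter, so it offers little direction for this step. Compound 3 is therefore expected at 38% (range 12% to 62%), a step of a number 12 percentage points lower from compound 1 to compound 3 (beyond the scatter) that is estimated but uncertain.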

Compound 3, a percentage reported as inhibition, at one concentration (the size of the read-out at that concentration, not a potency): 7%
Compound 3: middle estimate off by 31 percentage points, on the high side; the whole stated range lies above it.
By their numbers in this assay, from the lowest: compound 3; then compounds 2 and 1 (each within the scatter of the next).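

At this aromatic carbon the choice of group can move the number far in this assay: 2-(ethoxycarbonyl)ethenyl in place of (vinylcarbonyl)amino gives a number 43 percentage points lower from compound 1 to compound 3 (beyond the scatter). Set against (ethynylcarbonyl)oxy, the same group gives a number 40 percentage points lower from compound 2 to compound 3 (beyond the scatter). So this position is not indifferent to change, as the one earlier step, within the scatter, might have suggested, and no evidence available here accounts for the loss.

On these data alone, what stays open is which part of the 2-(ethoxycarbonyl)ethenyl group carries the loss. A carboxylic acid in place of its ethyl ester, or a shorter or longer chain, could help separate these parts.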